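Nitro to trichloromethyl: one change, two cores, acid dissociation

The source may hold more compounds than are shown below. What is called first, only, known or untested is meant among the compounds shown, and "the series" means these compounds.

Compound 1 `O=[N+]([O-])c1ccc(Oc2ccc(NC(=S)Oc3ccc(O)cc3)cc2)cc1` was measured in a physicochemical assay for acid dissociation, and gives 9.23. Compound 2 `CC(=O)Nc1ccc(OC(=S)Nc2ccc(Sc3ccc([N+](=O)[O-])cc3)cc2)cc1` gives 8.99 in this assay, and compound 3 `CC(=O)Nc1ccc(OC(=S)Nc2ccc(Sc3ccc(C(Cl)(Cl)Cl)cc3)cc2)cc1` gives 9.01; the three numbers lie within the scatter of one another. Compound 1 and compound 2 differ in more than one place, and the difference between the two cores is not broken down here. From compound 2 to compound 3 the change is trichloromethyl in place of nitro on an aromatic carbon, and it moved the value by a number 0.02 log units higher from compound 2 to compound 3 (within the scatter). Compound 4 `Oc1ccc(OC(=S)Nc2ccc(Oc3ccc(C(Cl)(Cl)Cl)cc3)cc2)cc1`, not yet measured, differs from compound 1 by trichloromethyl in place of nitro on an aromatic carbon, at the same place, so it is the same change. Because a number 0.02 log units higher from compound 2 to compound 3 (within the scatter) lies within the scatter, the expected step in this assay is a number 0.02 log units higher from compound 1 to compound 4 (within the scatter). Compound 4 is therefore estimated at 9.25, between 8.95 and 9.55.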

Compound 4, acid dissociation constant: 9.24
Estimate against measurement, compound 4: 0.01 log units above; measured number inside the range.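

In this assay, trichloromethyl in place of nitro on an aromatic carbon gives a number 0.01 log units higher from compound 1 to compound 4 (within the scatter), matching a number 0.02 log units higher from compound 2 to compound 3 (within the scatter) on the other core, so in these two pairs the step carries from one core to the other. Among the compounds shown here, both steps lie within the scatter, so this shows only that the two groups cannot be told apart in this assay on these two cores, not that the same would hold on any further core. Nothing shown accounts for this result.

The compounds shown leave open whether an amine or a carboxylic acid on that aromatic carbon would give a step of similar size in this assay.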